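From Propyl to Sec-Butyl in Compound 1

This account rests on a few compounds, and the source may have more. Where it says the series, first, only, none or still open, it means among the compounds named here.

Among the measured compounds shown here, in an in vivo ADME assay on the whole organism (strain Sprague-Dawley) for metabolic stability, with Rattus norvegicus as the target (a higher number here means that the compound lasts longer, a lower number that the compound disappears faster), compound 1 (`CCC[C@@H]1NC[C@@H](C)Oc2ccccc2CCCNC(=O)[C@@H](Cc2ccc(F)cc2)NC(=O)[C@@H](C)N(C)C1=O`) gives 29 h, the lower of the two numbers measured so far, while compound 2 (`C[C@@H]1C(=O)N[C@H](Cc2ccc(F)cc2)C(=O)NCCCc2cccc3c2O[C@H](CC3)CN[C@@H](C2CC2)C(=O)N1C`) gives 59 h. Compound 3 (`CC[C@H](C)[C@@H]1NC[C@@H](C)Oc2ccccc2CCCNC(=O)[C@@H](Cc2ccc(F)cc2)NC(=O)[C@@H](C)N(C)C1=O`) differs from compound 1 in one place: methyl in place of hydrogen on a saturated chain carbon bound to a saturated chain carbon and a saturated ring carbon, with methyl in place of hydrogen on a saturated chain carbon bound to a saturated chain carbon and a saturated ring carbon. For the measured compounds named here, no measured pair differs in one place, so no direct precedent exists. The expected step, a 1.2-fold higher number from compound 1 to compound 3 (0.08 log units; within the scatter), is a slight rise within the scatter. Compound 3 is estimated at 35 h, with an expected range from 18 h to 65 h.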

Compound 3, half-life: 44 h
Compound 3: middle estimate off by 1.3-fold (0.10 log units), on the low side; low and high end bracket the measured number.
By their numbers in this assay, from the lowest: compounds 1, 3 and 2 (each within the scatter of the next, the first and the last beyond it).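

Among the compounds shown here, the propyl to sec-butyl change, methyl in place of hydrogen on a saturated chain carbon bound to a saturated chain carbon and a saturated ring carbon, gives the first step that can be read at this position. In this assay it comes to a 1.5-fold higher number from compound 1 to compound 3 (0.18 log units; within the scatter) for this single methyl, so the half-life does not separate the two compounds. Nothing measured on hand bears on this result.

The compounds shown leave open whether a longer chain or an amine at this position would give a step beyond the scatter.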